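The source may report more compounds than this note shows. Statements on the series, on what has been measured and on what is new or still open speak of the compounds shown alone.

In a functional assay on HT-29 cells (Homo sapiens) for cytotoxicity, read by MTT assay, with a stated time of 72 h (on this read-out lower numbers stand for stronger inhibition of growth and higher numbers for weaker inhibition of growth), compound 3 `Sc1nc(NCc2ccccc2)c2ccccc2n1` gives 10100 nM, the lowest of the two numbers obtained so far; the nearest is compound 1 `CCCCC[Se]c1nc(NCc2ccc(SC)cc2)c2ccccc2n1`, which gives 83600 nM, a gap beyond the scatter. For compound 2 `CCCCC[Se]c1nc([Se]CCCCC)c2ccccc2n1` the assay reports only a limit, > 100000 nM. Compound 4 `CCCCC[Se]c1nc(NCc2ccccc2)c2ccccc2n1` is compound 3 with a group of 6 heavy atoms (5 carbon, 1 selenium; no ring) in place of one sulfur atom, on an aromatic carbon. Among the compounds with values here, no pair of measured compounds differs in one place alone, so this step is untested. Compound 1 carries the same entering group and gives 83600 nM, and on that basis a weakening beyond the scatter is expected here. The expected step of a 5.0-fold higher number from compound 3 to compound 4 (0.69 log units; beyond the scatter) would put compound 4 at an estimated 50000 nM, ranging from 15000 nM to 150000 nM.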

Compound 4, concentration for 50% growth inhibition: 72700 nM
Beside the measured number, compound 4's estimate is 1.5-fold (0.16 log units) below it; the measured number falls inside the stated range.
By their numbers in this assay, from the lowest: compound 3; then compounds 4 and 1 (each within the scatter of the next). At a limit, above all of these: compound 2.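

In this assay, a 7.2-fold higher number from compound 3 to compound 4 (0.86 log units; beyond the scatter) shows directly that this position, on an aromatic carbon between two ring nitrogen atoms, responds to the change from sulfanyl to the selenium-bearing chain. With that chain in place, hydrogen in place of methylsulfanyl on an aromatic carbon gives a 1.1-fold lower number from compound 1 to compound 4 (0.06 log units; within the scatter) and leaves the two compounds level. Compound 2 gives only a limit: the limit of > 100000 nM in this assay, at which 1 of the 4 values shown sits. Against that limit the comparison gives an at least 1.3-fold lower number from compound 2 to compound 4 (0.13 log units; that floor lies within the scatter), and this step cannot be read as a difference.

Still open, on these data alone, is whether the selenium or the chain matters more, since a sulfur-linked pentyl chain would separate them. As far as these compounds go, an amine or a carboxylic acid at this position also remains untested here.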